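Replacing the Urea Arm of a Potent Inhibitor

The source may hold more compounds than are shown below. What is called first, only, known or untested is meant among the compounds shown, and "the series" means these compounds.

Measured compounds:
compound 1 `COc1ccc(-c2cnc3nc(N)nc(N4CCN(C(=O)Nc5ccc(C)cc5)CC4)c3n2)cc1OC` — 0.8 nM
compound 2 `CCOc1nc(N)nc2ncc(-c3ccc(C(F)(F)F)cc3)nc12` — 10000 nM

In a functional assay on cells (T-cell, Homo sapiens) for inhibition (on this read-out higher numbers stand for weaker inhibition and lower numbers for stronger inhibition), compound 1 gives 0.8 nM, the lowest of the two numbers; compound 2 gives a far higher value, well beyond the scatter. Compound 3 `COc1ccc(-c2cnc3nc(N)nc(N4CCN(C(=O)COc5ccc(Cl)cc5)CC4)c3n2)cc1OC` keeps the core of compound 1 but carries a different arm: (4-chlorophenoxy)methyl in place of (4-methylphenyl)amino on a carbonyl carbon. For the measured compounds named here, no measured pair shows this change, so its effect is uncertain. A modest weakening of inhibition is expected, the step of a 6.3-fold higher number from compound 1 to compound 3 (0.80 log units; beyond the scatter) being small. Compound 3 is estimated at 5 nM, with a range from 1 nM to 30 nM.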

Compound 3, half-maximal inhibitory concentration: 0.5 nM
Estimate against measurement, compound 3: 10-fold (1.00 log units) above; the measured number lies below the stated range.
By their numbers in this assay, from the lowest: compounds 3 and 1 (each within the scatter of the next); then compound 2.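

In this assay, the change gives a 1.6-fold lower number from compound 1 to compound 3 (0.20 log units; within the scatter), so the two arms cannot be told apart on this read-out. In this pair, the arm on the carbonyl carbon can lose its hydrogen-bond donor and gain an oxygen and a chlorine while inhibition stays at this level. Nothing measured here explains why the two arms match. Which parts of the arm matter remains open, since its link and its ring substituent change together. Also open, as far as these compounds go, is whether a carboxylic acid or a longer chain would be tolerated on the same carbonyl carbon.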